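The source may hold more compounds than are shown below. What is called first, only, known or untested is meant among the compounds shown, and "the series" means these compounds.

Measured compounds:
Compound 1, `ClCc1ccccc1Cn1cnc2c(Cl)nc(Cl)nc21` — in a functional assay on SNB-75 cells (Homo sapiens) for cytotoxicity, read by sulforhodamine B assay, with a stated time of 48 h (on this read-out higher numbers stand for lower toxicity in this test and lower numbers for higher toxicity in this test), compound 1 gives "not determined" (no result reported), so no result is reported for it.
Compound 2, `Nc1nc(Cl)c2ncn(Cc3ccc(CCl)cc3)c2n1` — in this assay compound 2 gives > 100000 nM, which is a limit of the assay and not a number.

Compound 1 therefore stands nowhere on the numbers shown: it has no value of its own, and the only other value, that of compound 2, is a limit. Compound 2 differs from compound 1 in more than one place, so the pair shows only that one is without a result and the other is beyond the limit.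

Compound 3, `Nc1nc(Cl)c2ncn(Cc3ccccc3CCl)c2n1`, is not yet measured. It differs from compound 1 by amino in place of chloro on an aromatic carbon. For the measured compounds named here, since compound 1 has no value, no step from it can be sized or given a direction in this assay. Compound 2 shares the amino and chloro pattern of compound 3 and sits at the limit of > 100000 nM in this assay, at which 1 of the 2 values shown sits. Compound 3 is accordingly expected to give about 100000 nM, within a range of 30000 nM to 300000 nM, with a fair chance that only a limit is reported.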

Compound 3, concentration lethal to 50% of the cells: 64600 nM
Compound 3: the middle estimate sits 1.5-fold (0.19 log units) above what was measured; measured number inside the range.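

For the compounds shown here, compound 3 gives a number in this assay, but compound 1 has no reported result there, so no step between compound 1 and compound 3 can be read. The result for compound 2 is a limit and not a number: the limit of > 100000 nM in this assay, at which 1 of the 3 values shown sits.

The compounds shown leave open how far, and in which direction, amino in place of chloro shifts this read-out.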